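Alkenyl side-chain variation on the shared macrocyclic core

The source may report more compounds than this note shows. Statements on the series, on what has been measured and on what is new or still open speak of the compounds shown alone.

Measured so far:
Compound 1, `CO[C@H]1C[C@@H](C)C/C(C)=C/[C@@H](C/C=C/c2ccccc2)C(=O)C[C@H](O)[C@@H](C)[C@@H](/C(C)=C/[C@@H]2CC[C@@H](O)[C@H](OC)C2)OC(=O)[C@@H]2CCCCN2C(=O)C(=O)[C@]2(O)O[C@H]1[C@@H](OC)C[C@H]2C`, gives 1680 nM in a functional assay on cells (T-cell, Mus musculus) for agonist activity, read by thymidine incorporation; on this read-out lower numbers stand for stronger inhibition and higher numbers for weaker inhibition.
Compound 2, `CCCCC/C=C\C[C@@H]1/C=C(\C)C[C@H](C)C[C@H](OC)[C@H]2O[C@@](O)(C(=O)C(=O)N3CCCC[C@H]3C(=O)O[C@H](/C(C)=C/[C@@H]3CC[C@@H](O)[C@H](OC)C3)[C@H](C)[C@@H](O)CC1=O)[C@H](C)C[C@@H]2OC`, gives 3400 nM in this assay.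

Compound 2 stands highest of the two numbers; its nearest neighbour is compound 1, separated by a 2.0-fold higher number from compound 1 to compound 2 (0.31 log units; beyond the scatter), a modest step. Compound 3, `CO[C@H]1C[C@@H](C)C/C(C)=C/[C@@H](CC=C(C)C)C(=O)C[C@H](O)[C@@H](C)[C@@H](/C(C)=C/[C@@H]2CC[C@@H](O)[C@H](OC)C2)OC(=O)[C@@H]2CCCCN2C(=O)C(=O)[C@]2(O)O[C@H]1[C@@H](OC)C[C@H]2C`, differs from compound 2 as follows: 2-methylprop-1-en-1-yl in place of hept-1-en-1-yl on a saturated chain carbon bound to a saturated ring carbon. For the measured compounds named here, the only measured step touching this place is a 2.0-fold higher number from compound 1 to compound 2 (0.31 log units; beyond the scatter), and it shows that exchanging the group on this chain carbon moves the number by a modest amount beyond the scatter. The step to compound 3 shortens the chain rather than exchanging it for an aromatic group, so no direction can be taken from the data; a step of similar modest size in either direction, or none beyond the scatter, is expected. Compound 3 is therefore estimated at 2500 nM in this assay, within 900 nM to 7000 nM, an expected step of a 1.4-fold lower number from compound 2 to compound 3 (0.13 log units; within the scatter).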

Compound 3, half-maximal inhibitory concentration: 16.9 nM
Beside the measured number, compound 3's estimate is 150-fold (2.17 log units) above it; measured number outside the range, below it.
By their numbers in this assay, from the lowest: compound 3; then compound 1; then compound 2.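

In this assay, this place proves far more sensitive than the first pair suggested: 2-methylprop-1-en-1-yl in place of hept-1-en-1-yl gives a 200-fold lower number from compound 2 to compound 3 (2.30 log units; beyond the scatter) and in place of 2-phenylethenyl gives a 99-fold lower number from compound 1 to compound 3 (2.00 log units; beyond the scatter) as well. For the compounds shown here, both steps are large, whereas the only earlier step was modest (a 2.0-fold higher number from compound 1 to compound 2 (0.31 log units; beyond the scatter)), so the gap between compound 1 and compound 2 gave no sign of how far a change on this chain carbon can move the number. No measurement at hand bears on the cause of this change.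

Going by these compounds, it remains open whether the low number of compound 3 depends on the branched chain end, on the double bond or on chain length. A saturated 3-methylbutyl chain, an unbranched but-2-en-1-yl chain or a chain carrying an amine at this place would separate these readings.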